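Cytotoxicity notes on a small triazole-free-named aryl series

This account rests on a few compounds, and the source may have more. Where it says the series, first, only, none or still open, it means among the compounds named here.

Measured so far:
- compound 1 `COc1cc(OC)cc(-n2cc(-c3ccc(O)c(OC)c3)nn2)c1`: 10000 nM
- compound 2 `COc1cc(-c2cn(-c3ccc(Oc4ccccc4)cc3)nn2)cc(OC)c1OC`: 10000 nM
- compound 3 `COc1cc(-c2cn(-c3cc(OC)c(OC)c(OC)c3)nn2)ccc1O`: > 10000 nM

All three were read in a functional assay on MDA-MB-231 cells (Homo sapiens) for cytotoxicity, read by MTT assay; on this read-out lower numbers stand for stronger inhibition and higher numbers for weaker inhibition. Compound 1 gives 10000 nM there, and compound 2 gives 10000 nM, level with compound 1 at the digits printed and within the scatter. For compound 3 the assay reports only a limit, > 10000 nM, and not a number; this is the limit of > 10000 nM in this assay, at which 1 of the 3 values shown sits.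

Compound 3 and compound 1 differ in one place, (hydrogen in place of methoxy on an aromatic carbon), and the step is a number no higher from compound 3 to compound 1 (the limit leaves the size open). How the core of compound 2 differs from that of compound 3 is not broken down here.

Compound 4 `COc1ccc(-c2cn(-c3ccc(Oc4ccccc4)cc3)nn2)cc1OC` is not yet measured. Among the measured compounds shown here, it relates to compound 2 by hydrogen in place of methoxy on an aromatic carbon, the same kind of change as the one from compound 3 to compound 1, though not the same: in the earlier case the site was ortho to two methoxy groups and para to a large group, here it is ortho to a methoxy group, meta to a large group and meta to a methoxy group. Given the earlier step and the value of compound 2 10000 nM, the step of no change at the digits printed from compound 2 to compound 4 (within the scatter) in this assay is expected to stay within the scatter. Compound 4 is estimated at 10000 nM, between 4000 nM and 25000 nM, with a real chance that only a limit is reported.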

Compound 4, half-maximal inhibitory concentration: 10000 nM
Estimate against measurement, compound 4: no gap at the digits printed; low and high end bracket the measured number.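

In this assay, hydrogen in place of methoxy on an aromatic carbon gives no change at the digits printed from compound 2 to compound 4 (within the scatter), so on the core of compound 2 the removal of this methoxy leaves the read-out where it stood. Set beside the earlier case, the comparison between the two cores reads: the same change on two cores in this assay, a number no higher (the limit leaves the size open) from compound 3 to compound 1 and no change at the digits printed (within the scatter) from compound 2 to compound 4; the limit leaves it open whether they differ. Among the compounds shown here, compound 3 carries only a limit and not a number, so the series does not show that the change carries over from one core to the other with the same size, only that the two steps are not seen to disagree: the limit of > 10000 nM in this assay, at which 1 of the 4 values shown sits.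

The compounds shown leave open whether a group other than methoxy at this place, such as an amine, a carboxylic acid or a longer alkoxy chain, would move the read-out on either core. With every value at the same printed level or at a limit, they also leave open which part of these structures the read-out responds to at all.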